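Replacing the amine on the shared core: expecting compound 4

The source may report more compounds than this note shows. Statements on the series, on what has been measured and on what is new or still open speak of the compounds shown alone.

Compound 1 `Cc1ccc2c(NCc3ccc(NC(=O)C4CCN(Cc5cc(Cl)ccn5)CC4)cc3)nc(N(C)C)nc2c1`. In a functional assay on SV5A8 cells (Homo sapiens) for cytotoxicity (on this read-out lower numbers stand for stronger inhibition and higher numbers for weaker inhibition), compound 1 gives > 5400 nM, which is a limit of the assay.
Compound 2 `Cc1ccc2c(NCc3ccc(NC(=O)C4CCN(Cc5ccccc5)CC4)cc3)nc(N3CCC(N4CCCC4)CC3)nc2c1`. In this assay compound 2 gives > 8090 nM, which is a limit of the assay.
Compound 3 `Cc1ccc2c(NCc3ccc(NC(=O)C4CCN(C5CCCCC5)CC4)cc3)nc(N(C)C)nc2c1`. In this assay compound 3 gives > 8320 nM, which is a limit of the assay.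

All three measured compounds sit only at limits, so none of them can be placed against another; the numbers shown tell only that each one is weak in this assay. Compound 2 therefore stands at a limit and nowhere more exactly (the limit of > 8090 nM in this assay, at which 1 of the 3 values shown sits).

Compound 4 is `Cc1ccc2c(NCc3ccc(NC(=O)C4CCN(Cc5ccccc5)CC4)cc3)nc(N3CCNC(CCO)C3)nc2c1`. It differs from compound 2 in one place: 3-(2-hydroxyethyl)piperazin-1-yl in place of 4-(pyrrolidin-1-yl)piperidin-1-yl on an aromatic carbon. For the measured compounds named here, the only measured step that changes a single group is a step that the two limits leave unreadable from compound 1 to compound 3, and it alters a different part of the molecule, so it gives no guide to this change.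

With no readable step to lean on and compound 2 itself at a limit, compound 4 is expected to remain at or near that limit, so the expected step from compound 2 to compound 4 is a step that the limit leaves unreadable from compound 2 to compound 4. For compound 4 the estimate in this assay is 12000 nM, with a range from 3000 nM to 50000 nM, and a further limit rather than a number is the most likely outcome.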

Compound 4, half-maximal inhibitory concentration: > 8420 nM
Compound 4: a limit, no number; the forecaster's own chance of this, stated with the estimate: 75%; the middle value is on the limit's open side.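

In this assay compound 4 gives > 8420 nM, which is a limit of the assay and not a number. Compound 2 also stands at a limit, and the step between compound 2 and compound 4 cannot be read. The compounds shown leave open whether placing 3-(2-hydroxyethyl)piperazin-1-yl where 4-(pyrrolidin-1-yl)piperidin-1-yl stood changes cytotoxicity at all.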